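Exchanging one two-ring group for another

The source may report more compounds than this note shows. Statements on the series, on what has been measured and on what is new or still open speak of the compounds shown alone.

Of the compounds shown here, two sharing one core have numbers so far. In an ADME assay (liver) for metabolic stability, with Liver microsome (Rattus norvegicus) as the target, using microsomes and NADPH, with a stated time of 30 min, tested at 1 uM (a lower number here means slower removal, a higher number faster removal of the compound), compound 1 `Nc1ccc(S(=O)(=O)N2CCN(c3ncc(C(O)(C(F)(F)F)C(F)(F)F)cc3C#CC3CC3)CC2)cn1` gives 67 mL.min-1.g-1 and compound 2 `Nc1ccc(S(=O)(=O)N2CCN(c3ncc(C(O)(C(F)(F)F)C(F)(F)F)cc3-c3ccc4c(c3)CC(=O)N4)CC2)cn1` gives 119 mL.min-1.g-1, so these two values lie within the usual scatter of each other. Compound 3 `Nc1ccc(S(=O)(=O)N2CCN(c3ncc(C(O)(C(F)(F)F)C(F)(F)F)cc3-c3cccc4[nH]ncc34)CC2)cn1` has not yet been measured. It differs from compound 2 as follows: a group of 9 heavy atoms (7 carbon, 2 nitrogen; one five-membered aromatic ring with 2 hetero atoms, one six-membered aromatic ring of carbon only) in place of a group of 10 heavy atoms (8 carbon, 1 nitrogen, 1 oxygen; one five-membered non-aromatic ring with 1 hetero atom, one six-membered aromatic ring of carbon only), on an aromatic carbon. The exchange sits on an aromatic carbon of a six-membered aromatic ring with 1 nitrogen, ortho to a large group. Both groups hold a five-membered ring and a six-membered aromatic ring of carbon only, and their counts of hydrogen-bond donors and acceptors match. Within the data shown here, only one measured step bears on this, a change of group on that same carbon: a 1.8-fold higher number from compound 1 to compound 2 (0.25 log units; within the scatter). Among the measured compounds shown here, that step stayed within the scatter, and no measured pair exchanges these two particular groups, so the evidence is thin. The expected size of the new step in this assay is a 1.2-fold lower number from compound 2 to compound 3 (0.08 log units; within the scatter), which means no expected change beyond the scatter. For compound 3 the estimated value is 100 mL.min-1.g-1, with an expected range from 50 mL.min-1.g-1 to 190 mL.min-1.g-1.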

Compound 3, intrinsic clearance in microsomes: 93 mL.min-1.g-1
Estimate against measurement, compound 3: 1.1-fold (0.03 log units) above, and the stated range covers the measured number.
By their numbers in this assay, from the lowest: compounds 1, 3 and 2 (each within the scatter of the next).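

In this assay, 1H-indazol-4-yl on this carbon, in place of the group of compound 2 with its non-aromatic five-membered ring, gives a small step (a 1.3-fold lower number from compound 2 to compound 3 (0.11 log units; within the scatter)). The same 1H-indazol-4-yl in place of 2-cyclopropylethynyl also gives a small step (a 1.4-fold higher number from compound 1 to compound 3 (0.14 log units; within the scatter)), so all three groups at this position, ortho to a large group, now lie within the scatter of one another, even though one is a chain ending in a small ring and two hold fused rings. Among these three compounds, then, the exchange of this group has not moved the read-out clearly, and no separate measurement is available to explain the result.

On these data alone, it remains open whether any other group on this carbon, such as a simple amine or a carboxylic acid, would shift the number beyond the scatter. Also open, as far as these compounds go, is whether other parts of the shared core, such as the 2,2,2-trifluoro-1-hydroxy-1-(trifluoromethyl)ethyl group, have a larger effect on this number than this position does.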